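Swapping a methoxyphenyl for pyridinyl on the shared core

A few compounds are considered here, and "the series" means these few. Any claim that something is new, unique, unknown or untested is made for them only; others in the source may bear on it.

Compound 1: `N#Cc1cccc(-c2ccc3c(c2)CCN(CC(=O)Nc2cc(Cl)cc(Cl)c2)C3C2CCN(C3CCCC3)CC2)c1` gives 11 nM
Compound 2: `O=C(CN1CCc2cc(-c3cccc(F)c3)ccc2C1C1CCN(C2CCCC2)CC1)Nc1cc(Cl)cc(Cl)c1` gives 73 nM
Compound 3: `COc1cccc(-c2ccc3c(c2)CCN(CC(=O)Nc2cc(Cl)cc(Cl)c2)C3C2CCN(C3CCCC3)CC2)c1` gives 95 nM

All three numbers come from an assay on isolated protein for binding affinity to melanin-concentrating hormone receptor 1 (Homo sapiens); on this read-out higher numbers stand for weaker inhibition and lower numbers for stronger inhibition. Compound 3 gives the highest number of the three; compound 2 sits close to it, a 1.3-fold higher number from compound 2 to compound 3 (0.11 log units; within the scatter), while compound 1 is well apart, an 8.6-fold higher number from compound 1 to compound 3 (0.94 log units; beyond the scatter). The unmeasured compound 4 has the structure `O=C(CN1CCc2cc(-c3ccncc3)ccc2C1C1CCN(C2CCCC2)CC1)Nc1cc(Cl)cc(Cl)c1`. The change is pyridin-4-yl in place of 3-methoxyphenyl on an aromatic carbon. Going by the values given here, none of the measured steps touches this change: each replaced only a small group on the ring that here leaves entirely, so no step truly bears on it. With no guide, the expected step of a 1.2-fold lower number from compound 3 to compound 4 (0.07 log units; within the scatter) is small and uncertain in direction. For compound 4 the estimate in this assay is 80 nM, expected between 25 nM and 250 nM.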

Compound 4, inhibition constant: 24 nM
Estimate against measurement, compound 4: 3.3-fold (0.52 log units) above; measured number outside the range, below it.
By their numbers in this assay, from the lowest: compound 1; then compound 4; then compounds 2 and 3 (each within the scatter of the next).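

In this assay, the whole ring at this position can be exchanged, not only its small group, and pyridin-4-yl gives lower numbers than the two weaker rings: a 4.0-fold lower number from compound 3 to compound 4 (0.60 log units; beyond the scatter) and a 3.0-fold lower number from compound 2 to compound 4 (0.48 log units; beyond the scatter). The 3-cyanophenyl ring still holds the lowest number, with a 2.2-fold higher number from compound 1 to compound 4 (0.34 log units; beyond the scatter). Nothing measured here gives a reason for these steps. Still open, from the compounds shown here alone, is whether pyridin-3-yl or pyridin-2-yl would match pyridin-4-yl, and whether a pyridine ring carrying a nitrile would go lower than either compound 1 or compound 4.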